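The source may hold more compounds than are shown below. What is called first, only, known or untested is meant among the compounds shown, and "the series" means these compounds.

For the measured compounds named here, compound 1 `OC[C@H]1O[C@@H](n2cnc3c(NCc4ccc(F)cc4)ncnc32)[C@H](O)[C@@H]1O` is the only member of this small set with a number in an ADME assay on NIH3T3 cells (Mus musculus) for cytotoxicity, with a stated time of 72 h (a higher number here means a weaker inhibitor, a lower number a stronger inhibitor), where compound 1 gives 44300 nM. Compound 2 `COc1ccc(CNc2ncnc3c2ncn3[C@@H]2O[C@H](CO)[C@@H](O)[C@H]2O)c(OC)c1` shares the same sugar-bearing core, and in this assay compound 2 has only the entry "not determined" (no result reported) and no reported result, so compound 2 stands nowhere on the numbers shown and gives no anchor for the step that follows. Compound 3 `COc1cccc(CNc2ncnc3c2ncn3[C@@H]2O[C@H](CO)[C@@H](O)[C@H]2O)c1O` differs from compound 2 in one place: 2-hydroxy-3-methoxyphenyl in place of 2,4-dimethoxyphenyl on a saturated chain carbon bound to a nitrogen on an aromatic ring. Going by the values given here, with no measured pair to draw on, the step from compound 2 to compound 3 in this assay is expected to be of no clear direction and none beyond the usual scatter. Compound 3 is expected to come in near 40000 nM, with a range from 10000 nM to 150000 nM, because compound 1 gives 44300 nM in this assay.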

Compound 3, half-maximal inhibitory concentration: > 166000 nM
Compound 3 was reported as a limit; the forecaster's own chance of this, stated with the estimate: 30%; at least 4.1-fold (0.61 log units) between middle value and limit.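

In this assay the result for compound 3 is a limit and not a number: the limit of > 166000 nM in this assay, at which 1 of the 3 values shown sits. Even so, it gives the first reading at this position: 2-hydroxy-3-methoxyphenyl in place of 4-fluorophenyl on a saturated chain carbon bound to a nitrogen on an aromatic ring gives an at least 3.7-fold higher number from compound 1 to compound 3 (0.57 log units; beyond the scatter). The shared core stays the same in this step, so the change of aryl group alone is enough to move the number beyond the scatter, toward weaker inhibition.

Going by these compounds, the step between compound 2 and compound 3 cannot be read, so what 2,4-dimethoxyphenyl does here remains unknown. Also open, on these data alone, are the true value for compound 3 and how an amine or a carboxylic acid on the phenyl ring, or a longer chain at this place, would read.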